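Aryl Swap in a Histamine Agonist Series

The source may hold more compounds than are shown below. What is called first, only, known or untested is meant among the compounds shown, and "the series" means these compounds.

Measured in a functional assay on Right cardiac atrium for agonist activity at histamine H2 receptor (Cavia porcellus), with a stated time of 30 min, in the presence of a further agent that is not named here; on this read-out lower numbers stand for smaller maximal responses and higher numbers for larger maximal responses:
compound 1 `Cc1nc(N)sc1CCCN/C(N)=N/C(=S)NC(c1ccccc1)c1ccccc1` — 0.67
compound 2 `Cc1nc(N)sc1CCCN/C(N)=N/C(=O)NC(C)c1cccc(F)c1` — 0.85
compound 3 `Cc1nc(N)sc1CCCN/C(N)=N/C(=O)NC(c1ccccc1)c1ccccc1` — 0.9

Compound 2 stands second highest of the three values. Its nearest neighbour is compound 3, whose value lies within the scatter of it, so no order between the two can be claimed. Its furthest neighbour is compound 1, whose value is lower by more than the scatter.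

Compound 4 `Cc1nc(N)sc1CCCN/C(N)=N/C(=O)NC(C)c1ccc(Cl)cc1` is not yet measured. It differs from compound 2 in one place: 4-chlorophenyl in place of 3-fluorophenyl on a saturated chain carbon bound to an amide-type nitrogen and a saturated chain carbon. Going by the values given here, no step between measured compounds shows this change, so its effect can only be expected, not read off. Since the three measured values sit in a narrow band, compound 4 is expected to stay near compound 2, with a step of no change at the digits printed from compound 2 to compound 4 (within the scatter) that is not beyond the scatter. In this assay compound 4 is estimated at 0.85, between 0.7 and 0.95.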

Compound 4, intrinsic activity: the largest response reached, as a fraction of the reference agonist's: 0.93
Estimate against measurement, compound 4: 0.080 below; measured number inside the range.
By their numbers in this assay, from the lowest: compound 1; then compounds 2, 3 and 4 (each within the scatter of the next).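

In this assay, the first step seen at this position, 4-chlorophenyl in place of 3-fluorophenyl on a saturated chain carbon bound to an amide-type nitrogen and a saturated chain carbon, comes to a number 0.080 higher from compound 2 to compound 4 (within the scatter), so these two aryl groups cannot be ordered. This single step exchanges the halogen and its ring position together, and neither can be read alone. Nothing available accounts for the result. Still open, as far as these compounds go, is how a 4-fluorophenyl or an unsubstituted phenyl group would compare at this place.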